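This account rests on a few compounds, and the source may have more. Where it says the series, first, only, none or still open, it means among the compounds named here.

Series notes. Compound 1 `CCC[C@H](N)C(=O)N[C@@H](CC(C)C)B(O)O` and compound 3 `CCCC[C@H](N)C(=O)N[C@@H](CC(C)C)B(O)O` share one core; compound 2 `CC(C)C[C@H](NC(=O)[C@H](CO)NC(=O)c1cnccn1)B(O)O` and compound 4 `CC(C)C[C@H](NC(=O)[C@@H](NC(=O)c1cnccn1)[C@@H](C)O)B(O)O` share another. The difference between the two cores is not broken down here.

In an ADME assay on FSCLL cells (Homo sapiens) for cytotoxicity, read by MTT assay, with a stated time of 24 h (a lower number here means that less compound is tolerated, a higher number that more compound is tolerated), compound 1 gives 1100 nM, and compound 3 gives 950 nM; the step between them is a 1.2-fold lower number from compound 1 to compound 3 (0.06 log units; within the scatter). The change behind that step is methyl in place of hydrogen on a saturated chain carbon, four bonds along the chain from an amine nitrogen and a carbonyl carbon. In this assay compound 2 gives 210 nM, the lowest number of the three measured; its gaps to compound 3 and to compound 1 both lie beyond the scatter.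

Compound 4 carries methyl in place of hydrogen on a saturated chain carbon bound to an oxygen on a saturated carbon and a saturated chain carbon. This is the same kind of change as that from compound 1 to compound 3, not the same change: in compound 3 the methyl enters on a saturated chain carbon, four bonds along the chain from an amine nitrogen and a carbonyl carbon, whereas in compound 4 it enters on a saturated chain carbon bound to an oxygen on a saturated carbon and a saturated chain carbon. Among the compounds shown this methyl-for-hydrogen change occurs twice in all, once measured and once pending.

For the measured compounds named here, for compound 4 the expected step in this assay is a 1.0-fold higher number from compound 2 to compound 4 (0.02 log units; within the scatter), set beside the earlier step, because a 1.2-fold lower number from compound 1 to compound 3 (0.06 log units; within the scatter) lies within the scatter and is the only precedent, on a different core. Compound 4 is estimated at 220 nM, between 100 nM and 480 nM.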

Compound 4, half-maximal cytotoxic concentration: 100 nM
Compound 4: middle estimate off by 2.2-fold (0.34 log units), on the high side, and the stated range covers the measured number.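

In this assay, the methyl-for-hydrogen change that turns hydroxymethyl into 1-hydroxyethyl gives a 2.1-fold lower number from compound 2 to compound 4 (0.32 log units; beyond the scatter), a modest step on the core of compound 2. Set beside the only precedent, on the core of compound 1, the two steps cannot be told apart: the same change on two cores in this assay, a 1.2-fold lower number (0.06 log units; within the scatter) from compound 1 to compound 3 and a 2.1-fold lower number (0.32 log units; beyond the scatter) from compound 2 to compound 4, 1.8-fold (0.26 log units) apart, within the scatter of two such steps. For the compounds shown here, this shows that the two cores give no detectable disagreement for a methyl in place of hydrogen on a saturated chain carbon, but it does not show that a fixed step carries from one core to the other, since the evidence is only two pairs, one step lying within the scatter and the other beyond it, and the methyl enters at a different place in each.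

The compounds shown leave core and place of substitution tied together, so that neither can be judged alone, and the cause of the lower number for compound 4 stays open. Also open, on these data alone, is whether a longer chain, such as ethyl in place of the new methyl of compound 4, or an amine in place of its hydroxyl, would move the number further or leave it within the scatter.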